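Chloro on the anilino ring of compound 3

This account rests on a few compounds, and the source may have more. Where it says the series, first, only, none or still open, it means among the compounds named here.

Compound 3 `Cc1ccc(S(=O)(=O)Cc2nc(Nc3ccccc3)c3cc([N+](=O)[O-])ccc3n2)cc1` gives > 125000 nM in a functional assay on K562 cells (Homo sapiens) for cytotoxicity, read by flow cytometry, with a stated time of 72 h (on this read-out higher numbers stand for weaker inhibition and lower numbers for stronger inhibition), and that value is a limit, not a number. Compound 2 `Cc1ccc(S(=O)(=O)Cc2nc(Nc3ccc(F)cc3)c3ccccc3n2)cc1` gives > 20000 nM as a limit too. Compound 1 `Cc1ccc(S(=O)(=O)Cc2nc(Nc3ccccc3)c3ccccc3n2)cc1` has only the entry "nd(insoluble)" (no result reported) and no number. Compound 3 therefore offers no exact starting value. Compound 4 `Cc1ccc(S(=O)(=O)Cc2nc(Nc3cccc(Cl)c3)c3cc([N+](=O)[O-])ccc3n2)cc1` differs from compound 3 by chloro in place of hydrogen on an aromatic carbon meta to a large group, so phenyl becomes 3-chlorophenyl. No measured single change is available as a guide, so only a moderate gain in strength is expected in this assay and another limit would be no surprise. The expected move is an at least 3.1-fold lower number from compound 3 to compound 4 (0.49 log units; beyond the scatter) and it remains an estimate. Compound 4 is estimated at 40000 nM with 8000 nM to 130000 nM as the expected range.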

Compound 4, half-maximal inhibitory concentration: > 125000 nM
Compound 4: no number, only a limit; the forecaster's own chance of this, stated with the estimate: 50%; middle value at least 3.1-fold (0.49 log units) from the limit.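

Compound 3 and compound 4 each give only a limit, not a number, so the step between them cannot be read. On these data alone, whether chloro in place of hydrogen changes strength at all stays open.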